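Dimethylsulfamoyl on the phenyl of compound 2

The compounds below may be only part of what the source reports. "The series", "measured", "known", "first", "only" and "open" are said of these compounds alone.

In an ADME assay on microsomes from liver (Homo sapiens) for metabolic stability, read by LC-MS, with NADPH named in the record, with a stated time of 60 min, tested at 1 uM, in the absence of a further agent (a lower number here means that less of the compound is left, a higher number that more of the compound is left), compound 2 (`CC(=O)N[C@@H]1CCN(c2cc(C)nn3c(-c4ccccc4)c(C)nc23)C1`) is compared with compound 1 (`COc1ccc(-c2c(C)nc3c(N4CC[C@@H](NC(C)=O)C4)cc(C)nn23)cc1OC`) and compound 3 (`CC(=O)N[C@@H]1CCN(c2cc(C)nn3c(-c4ccc(C(F)(F)F)cc4)c(C)nc23)C1`), which share its core and differ only in the aryl group.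

Compound 2 gives > 95% which is a limit of the assay and not a number. Compound 1 gives > 95% which is likewise a limit. Compound 3 gives > 95% which is also a limit. For the measured compounds named here, the series so far stands at the limit of > 95% in this assay, at which 3 of the 3 values shown sit, with no number among them.

Compound 4 (`CC(=O)N[C@@H]1CCN(c2cc(C)nn3c(-c4cccc(S(=O)(=O)N(C)C)c4)c(C)nc23)C1`) departs from compound 2 by dimethylsulfamoyl in place of hydrogen on an aromatic carbon and this is dimethylsulfamoyl in place of hydrogen on an aromatic carbon, meta to a large group.

The nearest measured change is a step that the two limits leave unreadable from compound 2 to compound 3 and the change on the aryl group of compound 1 gives a step that the two limits leave unreadable from compound 1 to compound 2 so neither supplies a size. The expected step is a number at least 5 percentage points lower from compound 2 to compound 4 (that floor lies within the scatter) with no firm expectation of a move beyond the scatter, and any move would be downward. For compound 4 the estimated value is 90% with an expected range from 72% to 100% in this assay.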

Compound 4, percent of the compound remaining: > 95%
Compound 4 gave a limit, no number; the forecaster's own chance of this, stated with the estimate: 50%; at least 5 percentage points between middle value and limit.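

In this assay compound 4 gives > 95%, a limit and not a number, so the step from compound 2 to compound 4 cannot be read. The compounds shown leave open whether any change on the aryl group moves the percent remaining, with the whole series at one value: the limit of > 95% in this assay, at which 4 of the 4 values shown sit.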